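Taking one acyl group off compound 2

A few compounds are considered here, and "the series" means these few. Any claim that something is new, unique, unknown or untested is made for them only; others in the source may bear on it.

In a functional assay on MIA PaCa-2 cells (Homo sapiens) for inhibition, read by MTT assay, with a stated time of 24 h (on this read-out lower numbers stand for stronger inhibition of growth and higher numbers for weaker inhibition of growth), compound 1 (`N[C@@H](CC(=O)OC[C@H]1O[C@@H](n2cc(F)c(=O)[nH]c2=O)C[C@@H]1O)C(=O)O`) gives 3600000 nM. Compound 2 (`N[C@@H](CC(=O)OC[C@H]1O[C@@H](n2cc(F)c(=O)[nH]c2=O)C[C@@H]1OC(=O)C[C@H](N)C(=O)O)C(=O)O`) gives 2000000 nM, and compound 3 (`N[C@@H](CCC(=O)OC[C@H]1O[C@@H](n2cc(F)c(=O)[nH]c2=O)C[C@@H]1O)C(=O)O`) gives 2400000 nM. Compound 2 therefore stands within the scatter of both other compounds, and this small set shows no clear separation.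

Compound 4 (`N[C@@H](CC(=O)O[C@H]1C[C@H](n2cc(F)c(=O)[nH]c2=O)O[C@@H]1CO)C(=O)O`), not yet measured, has hydrogen in place of (2-amino-2-carboxyethyl)carbonyl on an oxygen on a saturated carbon. The closest measured evidence is the step that adds this same group on a different oxygen, a 1.8-fold lower number from compound 1 to compound 2 (0.26 log units; within the scatter). The step that changes the chain instead, a 1.5-fold lower number from compound 1 to compound 3 (0.18 log units; within the scatter), is also small. Neither step exceeds the scatter, so no step beyond the scatter is expected in this assay. The expected step is a 1.5-fold higher number from compound 2 to compound 4 (0.18 log units; within the scatter), a small rise that would remain within the scatter. For compound 4, the expected value is 3000000 nM, with an estimated range from 1500000 nM to 6000000 nM.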

Compound 4, concentration for 50% growth inhibition: 4100000 nM
For compound 4 the middle estimate is 1.4-fold (0.14 log units) below the measured one, and the stated range covers the measured number.
By their numbers in this assay, from the lowest: compounds 2, 3, 1 and 4 (each within the scatter of the next, the first and the last beyond it).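

In this assay, within the data shown here, changing (((2-amino-2-carboxyethyl)carbonyl)oxy)methyl to hydroxymethyl gives a 2.1-fold higher number from compound 2 to compound 4 (0.31 log units; beyond the scatter), the only step in this set that passes the scatter, and only modestly. The earlier step with the same group on the other oxygen, a 1.8-fold lower number from compound 1 to compound 2 (0.26 log units; within the scatter), stayed within the scatter, so the earlier compounds had shown no step of this size for this acyl group. The data shown offer nothing that accounts for the size of this step.

The compounds shown leave open whether this oxygen needs the amino acid part at all, since a plain acetyl ester at this place does not appear among them. They also leave open how an amide in place of the ester link, or a longer chain at this position, would read in this assay.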